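Removing a fluorine from a thioether-linked inhibitor

This account rests on a few compounds, and the source may have more. Where it says the series, first, only, none or still open, it means among the compounds named here.

Among the compounds with values here, compound 1 `O=C1C[C@H](O)C[C@@H](/C=C/c2cnc3c(F)c(F)c(F)cc3c2Sc2ccc(F)cc2)O1` is one of three compounds measured in an assay (strain Holtzman-Sprague-Dawley) for inhibition of 3-hydroxy-3-methylglutaryl-coenzyme A reductase (Rattus norvegicus), with a stated time of 30 min; a lower number here means a stronger inhibitor, a higher number a weaker inhibitor. Compound 1 gives 7930 nM, the second highest of the three numbers. The nearest is compound 2 `COc1cccc(Sc2cc3ncc(/C=C/[C@@H]4C[C@@H](O)CC(=O)O4)c(Sc4cccc(OC)c4)c3cc2F)c1`, which gives 3640 nM in this assay; the furthest is compound 3 `COc1cccc(Sc2c(F)cc3c(Sc4cccc(OC)c4)c(/C=C/[C@@H]4C[C@@H](O)CC(=O)O4)cnc3c2Sc2cccc(OC)c2)c1`, which gives 74600 nM in this assay. Within the data shown here, the only step between measured compounds that differ in a single place runs from compound 2 to compound 3: a 20-fold higher number from compound 2 to compound 3 (1.31 log units; beyond the scatter).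

Compound 4 `O=C1C[C@H](O)C[C@@H](/C=C/c2cnc3c(F)c(F)c(F)cc3c2Sc2ccccc2)O1` differs from compound 1 by hydrogen in place of fluoro on an aromatic carbon. Among the measured compounds shown here, no measured step bears directly on this change: the one step in the set concerns a (3-methoxyphenyl)sulfanyl group entering on an aromatic carbon, and its size says nothing about a fluoro group leaving the (4-fluorophenyl)sulfanyl arm. The expectation therefore rests on compound 1 alone. Losing one fluorine is a small change by heavy-atom count, and compound 4 is expected to sit close to compound 1, with a 1.0-fold higher number from compound 1 to compound 4 (0.00 log units; within the scatter) lying within the usual scatter of this assay. Compound 4 is estimated at 8000 nM in this assay, with a range from 3500 nM to 18000 nM.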

Compound 4, half-maximal inhibitory concentration: 10700 nM
The estimate for compound 4 lay 1.3-fold (0.13 log units) below the measured number, within the range that was stated.
By their numbers in this assay, from the lowest: compound 2; then compounds 1 and 4 (each within the scatter of the next); then compound 3.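

Replacing the fluoro group of the (4-fluorophenyl)sulfanyl arm with hydrogen gives a 1.3-fold higher number from compound 1 to compound 4 (0.13 log units; within the scatter) in this assay, so this read-out does not separate the two at this place on an aromatic carbon, para to a large group. Within the data shown here, the one step known earlier, a 20-fold higher number from compound 2 to compound 3 (1.31 log units; beyond the scatter) for a (3-methoxyphenyl)sulfanyl group entering on an aromatic carbon, concerned a different change; this new step is the first to read a change on the 4-fluorophenyl ring itself, and it shows that the phenylsulfanyl arm of compound 4 and the (4-fluorophenyl)sulfanyl arm of compound 1 stand within the scatter of each other on the shared core. No measurement is available that would account for this result.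

The compounds shown leave open whether a chlorine, an amine or a carboxylic acid at this same place would also stay within the scatter of compound 4. They also leave open whether the exchange of fluoro for hydrogen on this ring would read the same with a core carrying fewer fluoro groups than the core of compound 1.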